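Bromo-coumarin triazoles in A549 antiproliferative testing

The source may hold more compounds than are shown below. What is called first, only, known or untested is meant among the compounds shown, and "the series" means these compounds.

Measured compounds:
compound 1 `O=c1cc(-n2cc(-c3ccccc3)nn2)c2cc(Br)ccc2o1` with 11200 nM
compound 2 `O=c1cc(-n2cc(CNc3ccccc3)nn2)c2cc(Br)ccc2o1` with 13200 nM
compound 3 `O=c1cc(-n2cc(COc3cccnc3)nn2)c2cc(Br)ccc2o1` with 24800 nM

The three measured compounds share a core and differ only in the group on the triazole carbon. In a functional assay on A549 cells (Homo sapiens) for antiproliferative activity, read by MTT assay, with a stated time of 48 h (a lower number here means a stronger inhibitor, a higher number a weaker inhibitor), compound 3 gives the highest of the three numbers. Its step from compound 1 is a 2.2-fold higher number from compound 1 to compound 3 (0.35 log units; beyond the scatter), while the step from compound 2 is a 1.9-fold higher number from compound 2 to compound 3 (0.27 log units; within the scatter). Between compound 1 and compound 2 the step is a 1.2-fold higher number from compound 1 to compound 2 (0.07 log units; within the scatter), so the whole series spans only a narrow band.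

Compound 4 `O=c1cc(-n2cc(COc3ccccc3O)nn2)c2cc(Br)ccc2o1` is not yet measured. It differs from compound 3 in one place: 2-hydroxyphenyl in place of pyridin-3-yl on an oxygen on a saturated carbon. For the measured compounds named here, no measured step exchanges one aromatic ring for another on this oxygen; the nearest comparison is the step from compound 2 to compound 3, which swaps the whole group on the chain carbon and stays within the scatter. Given how little the earlier changes at this position moved the number, compound 4 is expected to stay close to compound 3, with a step of a 1.2-fold lower number from compound 3 to compound 4 (0.09 log units; within the scatter) that may fall either way but probably not beyond the scatter. Compound 4 is therefore estimated at 20000 nM in this assay, within a range from 9000 nM to 45000 nM.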

Compound 4, half-maximal inhibitory concentration: 7940 nM
Compound 4: middle estimate off by 2.5-fold (0.40 log units), on the high side; the whole stated range lies above it.
By their numbers in this assay, from the lowest: compounds 4, 1, 2 and 3 (each within the scatter of the next, the first and the last beyond it).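

In this assay, a 3.1-fold lower number from compound 3 to compound 4 (0.49 log units; beyond the scatter) shows that the ring on the oxygen can by itself carry a step beyond the scatter while the saturated carbon and its oxygen stay the same, whereas every earlier step exchanged the link and the ring together. The other new step, a 1.7-fold lower number from compound 2 to compound 4 (0.22 log units; within the scatter), stays within the scatter, so 2-hydroxyphenoxy and anilino on the saturated chain carbon cannot be told apart here, and at this position the change to 2-hydroxyphenoxy separates only from (pyridin-3-yl)oxy. The data shown offer no measurement that accounts for the step from the pyridin-3-yl ring to the 2-hydroxyphenyl ring.

This exchange removes the ring nitrogen and brings in a hydroxyl in a single move, so the compounds shown cannot say which of the two goes with the lower number. As far as these compounds go, a plain phenyl or a 2-methoxyphenyl on the same oxygen would bear on that question, and how an amine or a carboxylic acid in place of the hydroxyl would read also remains open.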